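Trifluoromethyl to fluoro: a step toward higher numbers?

A few compounds are considered here, and "the series" means these few. Any claim that something is new, unique, unknown or untested is made for them only; others in the source may bear on it.

In a functional assay on HepG2 cells (Homo sapiens) for cytotoxicity, read by MTT assay, with a stated time of 24 h (a lower number here means a stronger inhibitor, a higher number a weaker inhibitor), compound 1 `O=C1/C(=C/c2cccnc2)CN(S(=O)(=O)c2ccccc2)C/C1=C\c1ccccc1C(F)(F)F` gives 5370 nM, and compound 2 `O=C1/C(=C/c2cccnc2)CN(S(=O)(=O)c2ccc(C(F)(F)F)cc2)C/C1=C\c1ccccc1C(F)(F)F` gives 1710 nM, the lower of the two numbers. Compound 3 `O=C1/C(=C/c2cccnc2)CN(S(=O)(=O)c2ccc(F)cc2)C/C1=C\c1ccccc1C(F)(F)F` has fluoro in place of trifluoromethyl on an aromatic carbon, para to a large group: fluoro in place of trifluoromethyl on an aromatic carbon. Going by the values given here, the only measured step bearing on this change is a 3.1-fold lower number from compound 1 to compound 2 (0.50 log units; beyond the scatter), a modest one, for trifluoromethyl in place of hydrogen on an aromatic carbon. Part of that step is expected to be lost, giving an estimated 1.8-fold higher number from compound 2 to compound 3 (0.24 log units; within the scatter). For compound 3, the expected value is 3000 nM, with an estimated range of 1300 nM to 6000 nM.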

Compound 3, half-maximal inhibitory concentration: 2340 nM
Compound 3: the middle estimate sits 1.3-fold (0.11 log units) above what was measured; the range from low to high includes it.
By their numbers in this assay, from the lowest: compounds 2 and 3 (each within the scatter of the next); then compound 1.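

In this assay, fluoro in place of trifluoromethyl on this aromatic carbon, para to a large group, gives a 1.4-fold higher number from compound 2 to compound 3 (0.14 log units; within the scatter), so the two groups are not told apart here. Fluoro in place of hydrogen at the same position gives a 2.3-fold lower number from compound 1 to compound 3 (0.36 log units; beyond the scatter), so the step to a lower number is not confined to trifluoromethyl. No measurement at hand explains this. The compounds shown leave open whether an amine, a methoxy group or a carboxylic acid at this position would also keep the number low.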